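Acid to piperidine amide at the shared carbonyl carbon

This account rests on a few compounds, and the source may have more. Where it says the series, first, only, none or still open, it means among the compounds named here.

Two measured analogues share one core and differ only at a carbonyl carbon attached to an aromatic carbon. Compound 1 `COC(=O)c1cccn1-c1ccc(Nc2ncc(Cl)c(Nc3ccccc3NS(C)(=O)=O)n2)c(OC)c1` carries a methyl ester there; in a functional assay on A549 cells (Homo sapiens) for antiproliferative activity, read by MTT assay, with a stated time of 72 h (on this read-out higher numbers stand for weaker inhibition and lower numbers for stronger inhibition), compound 1 gives 2510 nM. Compound 2 `COc1cc(-n2cccc2C(=O)O)ccc1Nc1ncc(Cl)c(Nc2ccccc2NS(C)(=O)=O)n1` carries the free carboxy group; in this assay compound 2 gives 1060 nM. Going by the values given here, the single step available is a 2.4-fold lower number from compound 1 to compound 2 (0.37 log units; beyond the scatter). Among the two numbers compound 2 holds the lower one, with compound 1 as its only comparator.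

Compound 3 `COc1cc(-n2cccc2C(=O)N2CCCCC2)ccc1Nc1ncc(Cl)c(Nc2ccccc2NS(C)(=O)=O)n1` alters the same carbonyl carbon: piperidin-1-yl in place of hydroxy on a carbonyl carbon. Among the compounds with values here, no measured pair covers an amide at this position. Within the data shown here, the one step that bears on it, a 2.4-fold lower number from compound 1 to compound 2 (0.37 log units; beyond the scatter), shows that the number fell when the ester was opened to the acid, so masking the carboxy group again, this time as a piperidin-1-yl amide lacking the hydrogen-bond donor, is taken to run the other way by a modest amount, with little confidence that it exceeds the scatter. Compound 3 is therefore expected at 2000 nM, within 700 nM to 6000 nM. This estimate corresponds to an expected step of a 1.9-fold higher number from compound 2 to compound 3 (0.28 log units; within the scatter).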

Compound 3, half-maximal inhibitory concentration: > 10000 nM
Compound 3 was reported as a limit (the forecaster's own chance of this, stated with the estimate: 5%); at least 5.0-fold (0.69 log units) between middle value and limit.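

In this assay, compound 3 is reported only as a limit, not as a number: the limit of > 10000 nM in this assay, at which 1 of the 3 values shown sits. Even so, the limit is enough to order the series at this carbonyl carbon, with piperidin-1-yl in place of hydroxy giving an at least 9.4-fold higher number from compound 2 to compound 3 (0.97 log units; beyond the scatter), and piperidin-1-yl in place of methoxy giving an at least 3.9-fold higher number from compound 1 to compound 3 (0.60 log units; beyond the scatter). The ester and the acid had differed only modestly, so the position looked tolerant of change, whereas these steps show that the amide costs far more than the ester-to-acid change did, and that losing the hydroxy is not enough to reach this level, as compound 1 also lacks it and still gives 2510 nM.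

Going by these compounds, whether the loss belongs to the piperidin-1-yl ring or to an amide at this carbonyl carbon as such stays open, and a primary amide, a dimethylamino amide or a morpholin-4-yl amide would separate the two readings. On these data alone, how far compound 3 lies beyond its limit also remains unknown, so the true size of both steps is open.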